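A few compounds are considered here, and "the series" means these few. Any claim that something is new, unique, unknown or untested is made for them only; others in the source may bear on it.

Measured compounds:
Compound 1, `c1ccc(C2=NN(C3=NC(c4ccccc4)CS3)C(c3cccc4ccccc34)C2)cc1`, in a functional assay on BGC-823 cells (Homo sapiens) for inhibition, read by CCK-8 assay, with a stated time of 48 h (on this read-out lower numbers stand for stronger inhibition and higher numbers for weaker inhibition), gives 14300 nM.
Compound 2, `O=C1CSC(N2N=C(c3ccc(Cl)cc3)CC2c2cccc3ccccc23)=N1`, in this assay gives 16400 nM.
Compound 3, `c1ccc(C2=NN(C3=NC(c4ccccc4)CS3)C(c3ccc4ccccc4c3)C2)cc1`, in this assay gives 9620 nM.

Among these three numbers compound 1 stands second highest. Its nearest neighbour is compound 2, whose value lies within the scatter of the value of compound 1, so nothing can be said about an order between them. The furthest is compound 3, reached by exchanging naphthalen-2-yl for naphthalen-1-yl on a saturated ring carbon, and that step, a 1.5-fold lower number from compound 1 to compound 3 (0.17 log units; within the scatter), also stays within the scatter.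

Compound 4, `Cc1ccc(C2=NN(C3=NC(c4ccccc4)CS3)C(c3cccc4ccccc34)C2)cc1`, is not yet measured. It differs from compound 1 by methyl in place of hydrogen on an aromatic carbon. Among the measured compounds shown here, no measured step touches this phenyl ring: the only step recorded concerns the naphthyl group and was within the scatter, and compound 2 carries a different core and cannot be compared in one step. There is therefore no basis for expecting a move beyond the scatter in this assay in either direction.

Compound 4 is accordingly expected to give about 12000 nM, in a range from 5000 nM to 28000 nM, which would mean an estimated step of a 1.2-fold lower number from compound 1 to compound 4 (0.08 log units; within the scatter).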

Compound 4, half-maximal inhibitory concentration: 13300 nM
Beside the measured number, compound 4's estimate is 1.1-fold (0.04 log units) below it; low and high end bracket the measured number.
By their numbers in this assay, from the lowest: compounds 3, 4, 1 and 2 (each within the scatter of the next).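

Among the compounds shown here, the exchange of phenyl for 4-methylphenyl, a methyl on an aromatic carbon para to a large group, amounts to a 1.1-fold lower number from compound 1 to compound 4 (0.03 log units; within the scatter) in this assay, and it is the first step to touch this ring. So this single added carbon gives a number that cannot be told apart from that of compound 1, and this position tolerates the methyl without any readable consequence in this assay. Like the naphthyl exchange, a 1.5-fold lower number from compound 1 to compound 3 (0.17 log units; within the scatter), this step leaves the compounds close together, and no information is available that could bear on the result.

On these data alone, one small group says little about the position as a whole, so it remains open whether a methoxy group, an amine or a carboxylic acid in place of the methyl would give a number beyond the scatter. Compound 2 does carry a 4-chlorophenyl group, but it differs from compound 1 in more than one place and so cannot settle what a chlorine would do on the core of compound 1.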